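The compounds below may be only part of what the source reports. "The series", "measured", "known", "first", "only" and "open" are said of these compounds alone.

Working notes on the series. For the measured compounds named here, compound 1 `COc1cccc(NC(=O)Nc2cccc(-c3cccc4[nH]nc(N)c34)c2)c1` gives 2860 nM in a functional assay on SMMC-7721 cells (Homo sapiens) for inhibition, read by MTT assay, with a stated time of 48 h (on this read-out higher numbers stand for weaker inhibition and lower numbers for stronger inhibition), the highest of the two numbers so far; compound 2 `Nc1n[nH]c2cccc(-c3cccc(NC(=O)Nc4ccc(Cl)c(C(F)(F)F)c4)c3)c12` gives 1150 nM in this assay. Compound 3 `Cc1ccc(NC(=O)Nc2cccc(-c3cccc4[nH]nc(N)c34)c2)cc1Cl` is not yet measured. It differs from compound 1 by 3-chloro-4-methylphenyl in place of 3-methoxyphenyl on an amide-type nitrogen. Going by the values given here, with only two measured compounds and no step between them to lean on, the expected step from compound 1 to compound 3 is a 1.6-fold lower number from compound 1 to compound 3 (0.20 log units; within the scatter), a modest move toward a lower number that may still fall within the scatter. Compound 3 is estimated at 1800 nM, with a likely range of 800 nM to 4000 nM.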

Compound 3, half-maximal inhibitory concentration: 510 nM
For compound 3 the middle estimate is 3.5-fold (0.55 log units) above the measured one, and the stated range ends above it.
By their numbers in this assay, from the lowest: compound 3; then compound 2; then compound 1.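

For the compounds shown here, replacing 3-methoxyphenyl with 3-chloro-4-methylphenyl on an amide-type nitrogen gives a 5.6-fold lower number from compound 1 to compound 3 (0.75 log units; beyond the scatter) in this assay, the first readable step. With the shared core unchanged, this shows that the group at this place can shift the number beyond the scatter. Nothing at hand explains the step.

The chlorine and the methyl enter together, so the compounds shown do not separate their contributions. As far as these compounds go, how a phenyl ring carrying a carboxylic acid or a morpholine would read at this place also stays open.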